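The compounds below may be only part of what the source reports. "The series", "measured", "known", "first", "only" and "open" are said of these compounds alone.

In an ADME assay on RAW264.7 cells (Mus musculus) for cytotoxicity, read by MTT assay, with a stated time of 24 h, tested at 2.5 ug/mL (a lower number here means a stronger effect, a higher number a weaker effect of the compound at the concentration tested), compound 1, with structure `COc1ccc(CCCc2cccc(OC)c2OC)c(O)c1`, gives 99%. Compound 2, with structure `COc1cc(CCC(=O)c2cccc(O)c2)ccc1O`, gives 98.9% in this assay. Compound 1 has the higher of the two numbers, but the gap to compound 2 lies within the usual scatter, so the two cannot be told apart. Compound 3, with structure `COc1ccc(CCCc2ccc(OC)c(OC)c2OC)c(O)c1`, differs from compound 1 by methoxy in place of hydrogen on an aromatic carbon. Within the data shown here, with no measured step to lean on, no shift beyond the scatter is expected for the step of a number 2 percentage points lower from compound 1 to compound 3 (within the scatter). Compound 3 is thus expected to give about 97%, within a range from 88% to 102%.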

Compound 3, a percentage reported as activity, at one concentration (the size of the read-out at that concentration, not a potency): 95.5%
The estimate for compound 3 lay 1.5 percentage points above the measured number; low and high end bracket the measured number.
By their numbers in this assay, from the lowest: compounds 3, 2 and 1 (each within the scatter of the next).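

Among these compounds, the swap of hydrogen for methoxy on an aromatic carbon is the first single-place step here, and in this assay it gives a number 3.5 percentage points lower from compound 1 to compound 3 (within the scatter). This position, ortho to a methoxy group and para to a large group, therefore carries an added methoxy with no change that can be told from the scatter at the concentration tested. No available evidence bears on this result. From the compounds shown here alone, whether a different group here, such as an amine or a carboxylic acid, would also leave the read-out unchanged remains open.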